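Notes on compound 3: reversed amide with hydroxycyclohexyl

A few compounds are considered here, and "the series" means these few. Any claim that something is new, unique, unknown or untested is made for them only; others in the source may bear on it.

Compound 2 `Cc1cc(NC(=O)C2(F)CCNCC2)nn1Cc1cc(Cl)cc2cc(-c3ccccc3)oc12` in an assay on CHO-K1 cells for displacement of a labelled ligand from prostaglandin E2 receptor EP1 subtype (Homo sapiens), read by scintillation counting, with a stated time of 45 min (on this read-out higher numbers stand for weaker inhibition and lower numbers for stronger inhibition), gives 39.8 nM. Compound 1 `Cc1cc(NC(=O)CC2CCNCC2)nn1Cc1cc(Cl)cc2cc(-c3ccccc3)oc12` in this assay gives 63.1 nM; the step of a 1.6-fold lower number from compound 1 to compound 2 (0.20 log units; within the scatter) is within the scatter, so the two numbers stand together and compound 2 holds no separate place on them. Compound 3 `Cc1cc(C(=O)N[C@H]2CC[C@H](O)CC2)nn1Cc1cc(Cl)cc2cc(-c3ccccc3)oc12` differs from compound 2 by (4-hydroxycyclohexyl)carbamoyl in place of ((4-fluoropiperidin-4-yl)carbonyl)amino on an aromatic carbon. For the measured compounds named here, the only measured step, a 1.6-fold lower number from compound 1 to compound 2 (0.20 log units; within the scatter), concerns a change within the piperidine portion and leaves the amide direction and the ring type untouched, so it does not bear on this change. On these data alone, nothing measured here speaks to turning the amide around or to exchanging the ring, and the size of the step remains open. Without guidance, compound 3 is expected near 150 nM, with a broad range from 30 nM to 800 nM. The expected step is a 3.8-fold higher number from compound 2 to compound 3 (0.58 log units; beyond the scatter), leaning toward a higher number.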

Compound 3, half-maximal inhibitory concentration: 7.94 nM
For compound 3 the middle estimate is 19-fold (1.28 log units) above the measured one, outside the stated range (below it).
By their numbers in this assay, from the lowest: compound 3; then compounds 2 and 1 (each within the scatter of the next).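

In this assay, the group on the aromatic carbon of the five-membered aromatic ring with 2 nitrogen can be exchanged wholesale without loss: (4-hydroxycyclohexyl)carbamoyl gives a 5.0-fold lower number from compound 2 to compound 3 (0.70 log units; beyond the scatter) and a 7.9-fold lower number from compound 1 to compound 3 (0.90 log units; beyond the scatter). Both steps lie beyond the scatter, which the step between compound 1 and compound 2 did not, and they show that a ring of carbon only, with no ring nitrogen in this group, still reaches the lowest number of the series. No measured evidence accounts for this step.

The exchange alters the amide direction, the ring and its substituent at once, and the compounds shown leave open which of these carries the step. Also open, on these data alone, is how an amine or a carboxylic acid would read in place of the hydroxy group on the cyclohexyl ring.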